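The source may hold more compounds than are shown below. What is called first, only, known or untested is meant among the compounds shown, and "the series" means these compounds.

In a functional assay on DWD cells (Homo sapiens) for inhibition, read by sulforhodamine B assay (a higher number here means a weaker inhibitor of growth, a lower number a stronger inhibitor of growth), three compounds that share one core and differ in a single group on an aromatic carbon have been measured. The fluoro compound 1 `Fc1ccc(-c2ccc(-c3ccc(-c4nc5ccccc5[nH]4)cc3)cc2)cc1` gives 35600 nM. The trifluoromethyl compound 2 `FC(F)(F)c1ccc(-c2ccc(-c3ccc(-c4nc5ccccc5[nH]4)cc3)cc2)cc1` gives 100000 nM, and the hydroxy compound 3 `Oc1ccc(-c2ccc(-c3ccc(-c4nc5ccccc5[nH]4)cc3)cc2)cc1` gives 46300 nM. Compound 3 therefore sits within the scatter of the fluoro compound, a 1.3-fold higher number from compound 1 to compound 3 (0.11 log units; within the scatter), and has a modestly lower number than the trifluoromethyl compound, a 2.2-fold lower number from compound 2 to compound 3 (0.33 log units; beyond the scatter).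

Compound 4 `CN(C)c1ccc(-c2ccc(-c3ccc(-c4nc5ccccc5[nH]4)cc3)cc2)cc1` carries dimethylamino in place of hydroxy on an aromatic carbon. Within the data shown here, no measured compound carries this group, so the evidence is indirect. The largest measured swap at this place, a 2.8-fold higher number from compound 1 to compound 2 (0.45 log units; beyond the scatter), is itself only modest, and the measured numbers all lie close together. No step beyond the scatter, in either direction, is therefore expected in this assay. The expected step is a 1.0-fold lower number from compound 3 to compound 4 (0.01 log units; within the scatter). For compound 4 the estimated value is 45000 nM, with an expected range of 18000 nM to 100000 nM.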

Compound 4, concentration for 50% growth inhibition: 100000 nM
The estimate for compound 4 lay 2.2-fold (0.35 log units) below the measured number; the range from low to high includes it.
By their numbers in this assay, from the lowest: compounds 1 and 3 (each within the scatter of the next); then compounds 2 and 4 (each within the scatter of the next).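

In this assay, dimethylamino is the second group at this place, on an aromatic carbon para to a large group, to separate from hydroxy, with a 2.2-fold higher number from compound 3 to compound 4 (0.33 log units; beyond the scatter) and a 2.8-fold higher number from compound 1 to compound 4 (0.45 log units; beyond the scatter). It does not separate from trifluoromethyl, with no change at the digits printed from compound 2 to compound 4 (within the scatter), so two different groups now share the higher number and the four compounds fall into two pairs, compounds 1 and 3 and compounds 2 and 4. Nothing available here accounts for why dimethylamino falls with trifluoromethyl rather than with hydroxy or fluoro.

The compounds shown leave open how an unsubstituted amine, a methoxy group or a carboxylic acid would read at this place, and whether the split into two pairs would hold for them. They also leave open whether any group here could give a number clearly lower than those of compounds 1 and 3.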